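The compounds below may be only part of what the source reports. "The series", "measured", "known", "first", "only" and "open" are said of these compounds alone.

Three amides on one shared core have been run in a functional assay on HeLa cells (Homo sapiens) for antiproliferative activity, read by MTT assay, with a stated time of 72 h; on this read-out higher numbers stand for weaker inhibition and lower numbers for stronger inhibition. Compound 1 `O=C(Nc1ccc(Cl)c(-c2nnc3c(Cl)cccn23)c1)c1ccccn1` carries pyridin-2-yl on the carbonyl carbon; in this assay compound 1 gives 75500 nM. Compound 2 `O=C(Nc1ccc(Cl)c(-c2nnc3c(Cl)cccn23)c1)c1cccc(Cl)c1` carries 3-chlorophenyl there instead. In this assay compound 2 reaches only the limit > 100000 nM. Compound 3 `O=C(Nc1ccc(Cl)c(-c2nnc3c(Cl)cccn23)c1)c1ccccc1` carries a plain phenyl. In this assay compound 3 likewise reaches only the limit > 100000 nM. So compound 3 stands at the limit of > 100000 nM in this assay, at which 2 of the 3 values shown sit, and nothing more than a floor is known for it. The steps into it are floors as well: an at least 1.3-fold higher number from compound 1 to compound 3 (0.12 log units; that floor lies within the scatter), and an at least 1.3-fold higher number from compound 1 to compound 2 (0.12 log units; that floor lies within the scatter).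

Compound 4 `O=C(Nc1ccc(Cl)c(-c2nnc3c(Cl)cccn23)c1)c1ccccc1Cl` is the next member: chloro in place of hydrogen on an aromatic carbon, the chloro entering on an aromatic carbon of a six-membered aromatic ring of carbon only, ortho to a large group. Among the measured compounds shown here, the only measured step that bears on this change is the reverse move of a chloro on the same ring, a step that the two limits leave unreadable from compound 2 to compound 3, which the two limits leave unreadable. Both chloro-bearing and chloro-free phenyl amides sit at the limit, and no step beyond the scatter in this assay is indicated. Compound 4 is therefore expected to remain at or near the limit, an estimated step that the limit leaves unreadable from compound 3 to compound 4. The estimate for compound 4 is 150000 nM, ranging from 60000 nM to 400000 nM.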

Compound 4, half-maximal inhibitory concentration: > 100000 nM
Compound 4 ended at the assay's limit (the forecaster's own chance of this, stated with the estimate: 75%); the middle value does not contradict the limit.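

With chloro now on an aromatic carbon ortho to a large group, as well as in the 3-chlorophenyl amide compound 2, the phenyl amides still give no number in this assay: the limit of > 100000 nM in this assay, at which 3 of the 4 values shown sit. The steps from compound 3 to compound 4 and from compound 2 to compound 4 cannot be read, so neither adding the chloro nor going from 3-chlorophenyl to 2-chlorophenyl can be given a size. Among the compounds shown here, the one readable step is an at least 1.3-fold higher number from compound 1 to compound 4 (0.12 log units; that floor lies within the scatter), only a floor, and it does not separate the pyridin-2-yl amide from the 2-chlorophenyl amide.

Still open, going by these compounds, is whether an amine or a carboxylic acid in place of chloro on this six-membered ring would bring a value under the limit in this assay. Also open, on these data alone, is how far the three phenyl amides differ from one another, as all three are known only as limits.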